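Chloro for methoxy on a second core, estimated

The compounds below may be only part of what the source reports. "The series", "measured", "known", "first", "only" and "open" are said of these compounds alone.

Of the compounds shown here, three have been measured in a functional assay on DU-145 cells (Homo sapiens) for inhibition, read by trypan blue exclusion, with a stated time of 96 h; a higher number here means a weaker inhibitor of growth, a lower number a stronger inhibitor of growth. Compound 1 `COc1ccc(/C=C(/Sc2ccc(C)cc2)C(=O)c2ccc(Br)cc2)cc1` gives 50000 nM. Compound 2 `Cc1ccc(S/C(=C/c2ccc(Cl)cc2)C(=O)c2ccc(Br)cc2)cc1` gives 10000 nM. Between them stands one change, (chloro in place of methoxy on an aromatic carbon), and the step it made is a 5.0-fold lower number from compound 1 to compound 2 (0.70 log units; beyond the scatter). Compound 3 `COc1ccc(C(=O)/C(=C\c2ccc(Cl)cc2)S(=O)(=O)c2ccc(Cl)cc2)cc1` gives 4000 nM in this assay, the lowest of the three numbers; the difference between the core of compound 1 and the core of compound 3 is not broken down here.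

Compound 4 `O=C(/C(=C\c1ccc(Cl)cc1)S(=O)(=O)c1ccc(Cl)cc1)c1ccc(Cl)cc1` has not yet been measured. It differs from compound 3 by chloro in place of methoxy on an aromatic carbon, the same change, at the same kind of place, that was seen from compound 1 to compound 2. For the measured compounds named here, it is therefore expected to move the number in the same direction, and the estimate rests on the single step of a 5.0-fold lower number from compound 1 to compound 2 (0.70 log units; beyond the scatter) together with the value of compound 3, 4000 nM. Going by the values given here, because the only step of this kind seen so far is a 5.0-fold lower number from compound 1 to compound 2 (0.70 log units; beyond the scatter) and it was measured on a different core, the expected step is taken as somewhat smaller, a 2.7-fold lower number from compound 3 to compound 4 (0.43 log units; beyond the scatter). Compound 4 is expected to give about 1500 nM in this assay, with a likely range from 400 nM to 5000 nM.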

Compound 4, concentration for 50% growth inhibition: 25000 nM
Estimate against measurement, compound 4: 17-fold (1.22 log units) below; measured number outside the range, above it.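

The new step is a 6.3-fold higher number from compound 3 to compound 4 (0.80 log units; beyond the scatter) in this assay, so chloro in place of methoxy raised the number here, whereas it lowered the number on the earlier core. The change therefore did not carry from one core to the other, even in direction: the same change on two cores in this assay, a 5.0-fold lower number (0.70 log units; beyond the scatter) from compound 1 to compound 2 and a 6.3-fold higher number (0.80 log units; beyond the scatter) from compound 3 to compound 4, 31-fold (1.49 log units) apart, beyond the scatter of two such steps. This rests on a single pair on each core, so it shows that a step measured on one of these cores cannot simply be transferred to the other, but it does not show which difference between the cores reverses the step, or how the change would behave on a third core.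

The compounds shown leave open whether other groups at this place, such as an amine, a carboxylic acid or a longer chain, would also move the number in opposite directions on the two cores. They also leave open whether the change from 4-methoxyphenyl to 4-chlorophenyl would give a consistent step across further pairs on either core.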